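Adding an amino group to compound 2

The compounds below may be only part of what the source reports. "The series", "measured", "known", "first", "only" and "open" are said of these compounds alone.

Compound 1 `COc1cc(C(=O)c2cn(-c3ccccc3)cc2-c2ccccc2C)cc(OC)c1OC` gives 190 nM
Compound 2 `COc1cc(C(=O)c2cn(-c3ccccc3)cc2-c2ccccc2Cl)cc(OC)c1OC` gives 76 nM
Compound 3 `COc1cc(C(=O)c2cn(-c3ccccc3)cc2-c2cccc([N+](=O)[O-])c2)cc(OC)c1OC` gives 50 nM

In a functional assay on MCF7 cells (Homo sapiens) for cytotoxicity, read by MTT assay, with a stated time of 96 h (on this read-out lower numbers stand for stronger inhibition and higher numbers for weaker inhibition), compound 2 gives 76 nM as its value. The highest number stands clearly apart, with a 2.5-fold lower number from compound 1 to compound 2 (0.40 log units; beyond the scatter) on record, while the lowest does not, with a 1.5-fold lower number from compound 2 to compound 3 (0.18 log units; within the scatter) on record.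

The change to compound 4 `COc1cc(C(=O)c2cn(-c3cccc(N)c3)cc2-c2ccccc2Cl)cc(OC)c1OC` is amino in place of hydrogen on an aromatic carbon here, amino in place of hydrogen on an aromatic carbon, so that phenyl becomes 3-aminophenyl. Going by the values given here, no measured step touches this phenyl group. All three alter a different aryl substituent, so they guide only the likely size, and even a 3.8-fold lower number from compound 1 to compound 3 (0.58 log units; beyond the scatter) stays modest.

A modest step is therefore expected in this assay as well. The data fix no direction, so any lean towards a lower number is tentative, and the expected move is a 2.2-fold lower number from compound 2 to compound 4 (0.34 log units; beyond the scatter) in this estimate. Compound 4 is estimated at 35 nM with an expected range of 10 nM to 120 nM in this assay.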

Compound 4, half-maximal inhibitory concentration: 40 nM
Compound 4: middle estimate off by 1.1-fold (0.06 log units), on the low side, within the range that was stated.
By their numbers in this assay, from the lowest: compounds 4, 3 and 2 (each within the scatter of the next); then compound 1.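

Compound 4 is the first compound shown with a change at the phenyl group that becomes 3-aminophenyl, since compounds 1, 2 and 3 differ only in the other aryl group. In this assay, adding amino here gives (a 1.9-fold lower number from compound 2 to compound 4 (0.28 log units; within the scatter)), so the two compounds cannot be told apart, and this phenyl group can carry an amino group with no loss of activity beyond the usual scatter. No measured evidence here accounts for this result.

A single amino group cannot show how much this position tolerates, and a carboxylic acid, a hydroxyl group or a longer chain such as aminomethyl might behave differently here. From the compounds shown here alone, it also remains open whether amino would give a similar step on compound 1 or compound 3, which carry a different aryl group.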